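From ethyl to difluoromethyl: a clearance estimate

The source may hold more compounds than are shown below. What is called first, only, known or untested is meant among the compounds shown, and "the series" means these compounds.

Compound 1 (`CCC(c1ccc(Br)cc1)(C(C)O)n1ncc2c(NS(C)(=O)=O)cccc21`) gives 18 mL/min/kg
Compound 2 (`CCC(O)C(CC)(c1ccc(C(F)(F)F)cc1)n1ncc2c(NS(C)(=O)=O)cccc21`) gives 24 mL/min/kg

In an ADME assay for pharmacokinetics, with Rattus norvegicus as the target (on this read-out lower numbers stand for slow clearance and higher numbers for fast clearance), compound 2 gives 24 mL/min/kg and so sits within the usual scatter of compound 1. Compound 3 (`CCC(c1ccc(C(F)(F)F)cc1)(C(O)C(F)F)n1ncc2c(NS(C)(=O)=O)cccc21`) carries difluoromethyl in place of ethyl on a saturated chain carbon bound to an oxygen on a saturated carbon and a saturated chain carbon. Going by the values given here, no measured pair shows this swap, so the data give no direct guide, and no shift beyond the scatter is expected in this assay here. The expected step (a 1.2-fold lower number from compound 2 to compound 3 (0.08 log units; within the scatter)) is small and has no firm direction. For compound 3 the estimated clearance is 20 mL/min/kg with an expected range from 10 mL/min/kg to 40 mL/min/kg once it is measured.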

Compound 3, clearance: 3.8 mL/min/kg
Compound 3: middle estimate off by 5.3-fold (0.72 log units), on the high side, and the stated range ends above it.
By their numbers in this assay, from the lowest: compound 3; then compounds 1 and 2 (each within the scatter of the next).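

In this assay, difluoromethyl in place of ethyl on a saturated chain carbon bound to an oxygen on a saturated carbon and a saturated chain carbon gives a 6.3-fold lower number from compound 2 to compound 3 (0.80 log units; beyond the scatter) and lies beyond the usual scatter. Going by these compounds alone, this is the first measured pair that differs in one place only, and it shows that clearance depends on the group held at this position. Nothing available accounts for the shift. Going by these compounds, it remains open whether fluoromethyl or cyclopropyl in the same place would give a number as low as that of compound 3.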